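Azetidin-1-yl in Place of Cyclobutyloxy: Expecting Compound 4

A few compounds are considered here, and "the series" means these few. Any claim that something is new, unique, unknown or untested is made for them only; others in the source may bear on it.

Measured so far in a functional assay on cells (Lymphocyte, Homo sapiens), read by a luciferase reporter and ATP content, with a stated time of 48 h, tested at 5 uM; a lower number here means a stronger effect, a higher number a weaker effect of the compound at the concentration tested:
compound 1 `CCCCCCCCCCCCCCCCc1nc(N2CCC2)nc(OC2CCC2)c1O`: 114%
compound 2 `Cc1nc(OC2CCC2)nc(N2CCC2)c1O`: 99%
compound 3 `CCCCCCCCCCCCCCCCc1nc(OC2CCC2)nc(OC2CCC2)c1O`: 102%

One structural change has already been measured: a number 12 percentage points higher from compound 3 to compound 1 (beyond the scatter), a modest step beyond the scatter, arising from this difference: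
azetidin-1-yl in place of cyclobutyloxy on an aromatic carbon

Compound 2 and compound 3 share the same change in readout for compound 4, but the difference between their two cores is not broken down here; their values in this assay lie within the scatter of each other.

Compound 4 `Cc1nc(N2CCC2)nc(N2CCC2)c1O` has not been measured. It differs from compound 2 as follows:
azetidin-1-yl in place of cyclobutyloxy on an aromatic carbon

The surroundings differ from the earlier case: in compound 3 the place is meta to a cyclobutyloxy group and meta to a large group, whereas in compound 2 it is meta to a methyl group and meta to an azetidin-1-yl group, so this is the same kind of change, not the same change. The step of a number 11 percentage points higher from compound 2 to compound 4 (beyond the scatter) is expected to be about as large as the earlier step, because compound 3 to compound 1 gave a number 12 percentage points higher from compound 3 to compound 1 (beyond the scatter) for the same kind of change. Compound 4 is estimated at 110%, expected between 98% and 122%.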

Compound 4, a percentage reported as activity, at one concentration (the size of the read-out at that concentration, not a potency): 101%
Beside the measured number, compound 4's estimate is 9 percentage points above it; measured number inside the range.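

In this assay, putting azetidin-1-yl in place of cyclobutyloxy gave a number 2 percentage points higher from compound 2 to compound 4 (within the scatter), so on this core the change has no effect that stands out from the scatter. Among these compounds, the two cores cannot be told apart for this change: the same change on two cores in this assay, a number 12 percentage points higher (beyond the scatter) from compound 3 to compound 1 and a number 2 percentage points higher (within the scatter) from compound 2 to compound 4, 10 percentage points apart, within the scatter of two such steps This does not show that the change acts identically on both cores, only that these two pairs give no firm sign of a difference, and a single pair per core is thin evidence either way.

The compounds shown leave open whether a different group in the same place, such as a dimethylamino group or a methoxy group, would shift the read-out more clearly. They also leave open how a chain of middling length, such as butyl, would behave in place of the methyl group.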